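The compounds below may be only part of what the source reports. "The series", "measured", "known", "first", "only" and "open" are said of these compounds alone.

Measured compounds in a functional assay on the whole organism for inhibition, with Rattus norvegicus as the target, read by paw edema, with a stated time of 30 min, at a dose of 40 mg/kg by the oral route; a higher number here means a stronger effect of the compound at the dose given, a lower number a weaker effect:
Compound 1, `Cc1ccccc1OCC1=NCCO1`, gives 29.5%.
Compound 2, `Clc1ccccc1OCC1=NCCO1`, gives 22.2%.
Compound 3, `O=[N+]([O-])c1ccccc1OCC1=NCCO1`, gives 35.5%.

Within the data shown here, compound 1 stands second highest of these three numbers, but the steps of a number 6 percentage points higher from compound 1 to compound 3 (within the scatter) and a number 7.3 percentage points lower from compound 1 to compound 2 (within the scatter) both lie within the scatter, so its place among them is not secure; only the step of a number 13.3 percentage points higher from compound 2 to compound 3 (beyond the scatter) reaches beyond the scatter. Compound 4, `Cc1ccc(OCC2=NCCO2)c(C)c1`, differs from compound 1 by methyl in place of hydrogen on an aromatic carbon. Among the measured compounds shown here, no measured step adds a second group to a bare aromatic carbon; all three swap one group for another, and two of those swaps stayed within the scatter. Without a closer precedent, the expectation is no step beyond the scatter, neither up nor down. Compound 4 is therefore estimated at 30%, with a range from 18% to 42%, meaning an expected step of a number 0.5 percentage points higher from compound 1 to compound 4 (within the scatter).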

Compound 4, a percentage reported as inhibition, in the whole organism at one dose (the size of the read-out at that dose, not a potency): 46.5%
Compound 4: the middle estimate sits 16.5 percentage points below what was measured; measured number above the stated range.
By their numbers in this assay, from the lowest: compounds 2, 1 and 3 (each within the scatter of the next, the first and the last beyond it); then compound 4.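

In this assay, methyl in place of hydrogen gives a number 17 percentage points higher from compound 1 to compound 4 (beyond the scatter), the first step away from compound 1 that goes beyond the scatter. The earlier steps shown here swapped one group for another at a single carbon, whereas this one fills a different aromatic carbon, para to a group of 7 heavy atoms, and shows that a single added methyl there can raise the read-out. Nothing available explains the rise. Going by these compounds, whether ethyl, methoxy or an amine at this carbon would act like methyl stays open. So does whether the rise depends on the methyl group already present in compound 1.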